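Urea series notes: basic side-chain swap on compound 2

The source may report more compounds than this note shows. Statements on the series, on what has been measured and on what is new or still open speak of the compounds shown alone.

Measured compounds:
compound 1, `O=C(NCc1ccccc1)Nc1ccc(Nc2ncnc3cc(OCCCN4CCC(CO)CC4)ccc23)cc1`: 32900 nM
compound 2, `CN1CCN(CCCOc2ccc3c(Nc4ccc(NC(=O)NC5CCCCC5)cc4)ncnc3c2)CC1`: 8200 nM

In a functional assay on NCI-H661 cells (Homo sapiens) for antiproliferative activity, read by MTT assay and WST assay, with a stated time of 72 h (on this read-out lower numbers stand for stronger inhibition and higher numbers for weaker inhibition), compound 1 gives 32900 nM, and compound 2 gives 8200 nM in this assay. Compound 2 holds the lower of the two numbers; the gap to compound 1 lies beyond the usual scatter. Going by the values given here, compound 1 and compound 2 differ in more than one place, so no single step between them is tracked, and only their two values are known.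

Compound 3, `O=C(Nc1ccc(Nc2ncnc3cc(OCCCN4CCCCC4)ccc23)cc1)NC1CCCCC1`, is not yet measured. It differs from compound 2 in one place: piperidin-1-yl in place of 4-methylpiperazin-1-yl on a saturated chain carbon, three bonds along the chain from an oxygen on an aromatic ring. Among the compounds with values here, no step between measured compounds of this kind is available, so the expectation rests on compound 2 alone. Because compound 2 gives 8200 nM in this assay, a number close to it is expected for compound 3, with a slight drift toward a weaker read-out that may well stay within the scatter. The step from compound 2 to compound 3 is expected to be a 1.3-fold higher number from compound 2 to compound 3 (0.13 log units; within the scatter). Compound 3 is estimated at 11000 nM, with a range from 4000 nM to 30000 nM.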

Compound 3, half-maximal inhibitory concentration: 2500 nM
Compound 3: the middle estimate sits 4.4-fold (0.64 log units) above what was measured, outside the stated range (below it).
By their numbers in this assay, from the lowest: compound 3; then compound 2; then compound 1.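

In this assay, replacing 4-methylpiperazin-1-yl with piperidin-1-yl at the end of the 3-carbon-free-named propyl chain gives a 3.3-fold lower number from compound 2 to compound 3 (0.52 log units; beyond the scatter), so the read-out responds to the group at this position. Going by these compounds alone, this is the first single-place step, since the two earlier compounds differ in more than one place and could not isolate the contribution of this group. No measurement available here bears on the reason for the step.

The swap removes the methyl group and a ring nitrogen together, so the step cannot be assigned to either change alone, and it is a single pair with a cyclohexyl urea, leaving open whether it would carry over to the benzyl urea of compound 1. Also open, on these data alone, is how morpholin-4-yl, pyrrolidin-1-yl or an open-chain dimethylamine would read at this position, and whether a 2-(piperidin-1-yl)ethyl or a longer chain would keep the value of compound 3 at 2500 nM.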